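A Methyl Added to Compound 3

This account rests on a few compounds, and the source may have more. Where it says the series, first, only, none or still open, it means among the compounds named here.

Of the compounds shown here, three have so far been measured in an assay on membranes from HEK293 cells for displacement of a labelled ligand from adenosine receptor A2b (Homo sapiens), read by scintillation counting, with a stated time of 30 min, tested at 1 uM; on this read-out lower numbers stand for less inhibition and higher numbers for more inhibition at the one concentration tested (going by the name of the read-out). Compound 1 `CCCOC(=O)C1=C(C)NC(=S)NC1c1ccoc1` gives 45%, compound 2 `CC1=C(C(=O)OCC(C)C)C(c2ccsc2)NC(=S)N1` gives 15%, and compound 3 `CCNC(=O)C1=C(C)NC(=O)NC1c1ccco1` gives 1%. Compound 3 stands lowest of the three: the nearest number belongs to compound 2 and the furthest to compound 1, and both gaps lie beyond the usual scatter. Compound 4 `CC1=C(C(=O)NC(C)C)C(c2ccco2)NC(=O)N1` has not yet been measured. It differs from compound 3 in one place: methyl in place of hydrogen on a saturated chain carbon bound to an amide-type nitrogen and a saturated chain carbon. Going by the values given here, no step between two measured compounds shows what such an addition does here, so the expectation rests on compound 3 alone. The expected change is a number 2 percentage points higher from compound 3 to compound 4 (within the scatter), a step small enough to stay within the scatter. Compound 4 is therefore estimated at 3%, with a range from -8% to 15%.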

Compound 4, a percentage reported as inhibition, at one concentration (the size of the read-out at that concentration, not a potency): 2%
Compound 4: middle estimate off by 1 percentage points, on the high side; the range from low to high includes it.
By their numbers in this assay, from the lowest: compounds 3 and 4 (each within the scatter of the next); then compound 2; then compound 1.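

In this assay, changing ethylcarbamoyl to isopropylcarbamoyl gives a number 1 percentage points higher from compound 3 to compound 4 (within the scatter). Going by these compounds alone, this is the first readable step at this position, and it shows that this added methyl, on the saturated chain carbon bound to the amide-type nitrogen, does not move the number beyond the usual scatter. No outside evidence bears on this result.

Going by these compounds, whether a longer chain such as butyl, or an amine on this chain, would shift the number remains open. So does whether the same methyl addition would behave alike on another core.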